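A few compounds are considered here, and "the series" means these few. Any claim that something is new, unique, unknown or untested is made for them only; others in the source may bear on it.

Series notes, adenosine receptor displacement. Among the compounds with values here, compound 3 `Cn1c(-c2cccnc2)nc2c(NC3CCCC3)ncnc21` stands at the high end of the three numbers so far: in an assay on CHO cells for displacement of a labelled ligand from adenosine receptor A1 (Homo sapiens), read by scintillation counting, with a stated time of 3 h (a lower number here means a stronger inhibitor, a higher number a weaker inhibitor), compound 3 gives 242 nM, while compound 1 `CCCn1c(-c2ccccc2)nc2c(NC3CCCC3)ncnc21` gives 10 nM and compound 2 `Cc1ccc(-c2nc3c(NC4CCCC4)ncnc3n2C)cc1` gives 8 nM. Both gaps to compound 3 are well beyond the scatter. Within the data shown here, the one single-point step among measured compounds is a 30-fold higher number from compound 2 to compound 3 (1.48 log units; beyond the scatter), the swap of the aryl group on the shared core being the only change there.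

The next step, from compound 3 to compound 4 `Cn1c(-c2ccccc2)nc2c(NC3CCCC3)ncnc21`, is phenyl in place of pyridin-3-yl on an aromatic carbon. It reverses the kind of change seen in the step from compound 2 to compound 3, removing the ring nitrogen of the aryl group while the methyl on the core is kept. Compound 4 also differs from compound 1 only in methyl in place of propyl on the core, and compound 1 sits close to compound 2. A large drop in number is therefore expected, on the order of the step already seen, i.e. a 20-fold lower number from compound 3 to compound 4 (1.30 log units; beyond the scatter) is the expected step. Compound 4 is estimated at 12 nM in this assay, within 5 nM to 35 nM.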

Compound 4, inhibition constant: 2.8 nM
Compound 4: middle estimate off by 4.3-fold (0.63 log units), on the high side, outside the stated range (below it).
By their numbers in this assay, from the lowest: compound 4; then compounds 2 and 1 (each within the scatter of the next); then compound 3.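

Within the data shown here, with the methyl on the core kept, the single swap at this aromatic carbon in this assay gives an 86-fold lower number from compound 3 to compound 4 (1.94 log units; beyond the scatter), so the large loss seen with pyridin-3-yl also appears against unsubstituted phenyl, not only against 4-methylphenyl. Phenyl with the core methyl also gives the lowest number of the four, with a 2.9-fold lower number from compound 2 to compound 4 (0.46 log units; beyond the scatter) when the methyl leaves the aryl ring and a 3.6-fold lower number from compound 1 to compound 4 (0.55 log units; beyond the scatter) when propyl on the core is shortened to methyl, both modest next to the change in the aryl ring. No measurement here bears on why these changes shift the number.

On these data alone, it remains open how a methoxy group or an amine on the phenyl ring would compare with hydrogen and methyl. As far as these compounds go, an ethyl or a chain longer than propyl on the core also remains untested against this methyl and propyl pair.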